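A chlorine moved to the other benzyl group

This account rests on a few compounds, and the source may have more. Where it says the series, first, only, none or still open, it means among the compounds named here.

Of the compounds shown here, three sharing one core have been tested for how much of them cells tolerate. Compound 1 `O=C1c2ccccc2N(Cc2ccccc2)S(=O)(=O)N1Cc1ccc(Cl)cc1` carries a chloro group on one of its two benzyl arms; in a functional assay on HEL cells (Homo sapiens) for inhibition (a higher number here means that more compound is tolerated, a lower number that less compound is tolerated), compound 1 gives 121000 nM. Compound 2 `O=C1c2ccccc2N(Cc2ccccc2)S(=O)(=O)N1Cc1ccccc1` lacks that chloro group. In this assay compound 2 reaches only a limit of the assay, > 200000 nM. Compound 3 `O=C1c2ccccc2N(Cc2ccccc2)S(=O)(=O)N1Cc1ccccc1Cl` is another chloro-bearing variant. In this assay compound 3 likewise stops at a limit, > 200000 nM. Compound 2 thus stands at the edge of what this assay reports, a position it shares with one other compound (the limit of > 200000 nM in this assay, at which 2 of the 3 values shown sit).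

Compound 4 `O=C1c2ccccc2N(Cc2ccc(Cl)cc2)S(=O)(=O)N1Cc1ccccc1` has not been measured. From compound 2 the change is chloro in place of hydrogen on an aromatic carbon. Two measured steps resemble it: an at least 1.6-fold higher number from compound 1 to compound 2 (0.21 log units; that floor lies within the scatter) runs the opposite way, and a step that the two limits leave unreadable from compound 2 to compound 3. Neither yields a readable size, and both are compatible with no change beyond the scatter. The step of an at least 1.1-fold lower number from compound 2 to compound 4 (0.07 log units; that floor lies within the scatter) is therefore expected to stay within the scatter. Compound 4 is estimated at 170000 nM, ranging from 80000 nM to 350000 nM, with a real chance that this assay again reports only a limit.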

Compound 4, half-maximal cytotoxic concentration: > 200000 nM
Compound 4 was reported as a limit; the forecaster's own chance of this, stated with the estimate: 50%; middle value at least 1.1-fold (0.07 log units) away from the limit.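

Among the compounds shown here, compound 2 and compound 4 both stop at a limit of the assay, so no step between them can be read. The compounds shown leave open how much of compound 2, compound 3 or compound 4 is actually tolerated in this assay, and so whether chloro in place of hydrogen changes that number at all.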